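Chloro in place of nitro, starting from compound 3

The compounds below may be only part of what the source reports. "The series", "measured", "known", "first", "only" and "open" are said of these compounds alone.

In a functional assay on MCF7 cells (Homo sapiens) for antiproliferative activity, read by MTT assay, with a stated time of 48 h (on this read-out lower numbers stand for stronger inhibition and higher numbers for weaker inhibition), compound 3 `O=[N+]([O-])c1cccc(-c2nn(-c3ccccc3)cc2C(Nc2nc3ccc(Cl)cc3s2)c2c(O)ccc3ccccc23)c1` gives 19700 nM. That places it within the scatter of compound 2 `Oc1ccc2ccccc2c1C(Nc1nc2ccccc2s1)c1cn(-c2ccccc2)nc1-c1cccc(Cl)c1` at 20700 nM and of compound 1 `Cc1ccc2nc(NC(c3cn(-c4ccccc4)nc3-c3cccc([N+](=O)[O-])c3)c3c(O)ccc4ccccc34)sc2c1` at 38400 nM, so the three numbers cannot be ranked. The next structure, compound 4 `Oc1ccc2ccccc2c1C(Nc1nc2ccc(Cl)cc2s1)c1cn(-c2ccccc2)nc1-c1cccc(Cl)c1`, is compound 3 with chloro in place of nitro on an aromatic carbon, meta to a large group: chloro in place of nitro on an aromatic carbon. Within the data shown here, no measured pair shows this exchange directly. Among the measured compounds shown here, the one measured step, a 1.9-fold lower number from compound 1 to compound 3 (0.29 log units; within the scatter), is a different exchange, chloro in place of methyl on an aromatic carbon, and it stays within the scatter. Compound 2 already carries the 3-chlorophenyl and stands at 20700 nM, which offers no sign of a shift tied to that group. In this assay no step beyond the scatter is therefore expected, and the estimated step is a 1.0-fold lower number from compound 3 to compound 4 (0.02 log units; within the scatter). For compound 4 the expected value is 19000 nM, with an estimated range of 9500 nM to 38000 nM.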

Compound 4, half-maximal inhibitory concentration: 17500 nM
Compound 4: middle estimate off by 1.1-fold (0.04 log units), on the high side, and the stated range covers the measured number.
By their numbers in this assay, from the lowest: compounds 4, 3, 2 and 1 (each within the scatter of the next, the first and the last beyond it).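

In this assay, the exchange of 3-nitrophenyl for 3-chlorophenyl can now be read directly, as a 1.1-fold lower number from compound 3 to compound 4 (0.05 log units; within the scatter), so this aromatic carbon, meta to a large group, tolerates either nitro or chloro without a step beyond the scatter. The second new pair adds a different exchange on the other side of the molecule: the addition of one chloro gives a 1.2-fold lower number from compound 2 to compound 4 (0.07 log units; within the scatter), so that chloro, too, brings no step beyond the scatter here. No evidence is available to explain why these exchanges stay so small.

The compounds shown leave open whether an amine or a carboxylic acid in place of the nitro or chloro on the phenyl ring would shift the number beyond the scatter. They also leave open whether a longer chain at the other chloro-bearing carbon would do so.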